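The compounds below may be only part of what the source reports. "The series", "measured", "known", "first", "only" and "open" are said of these compounds alone.

In an ADME assay on MT4 cells (Homo sapiens) for cytotoxicity (on this read-out higher numbers stand for lower toxicity in this test and lower numbers for higher toxicity in this test), two compounds have been measured so far. Compound 1 `FC(F)(F)c1cccc(NC(=S)Nc2ccc(I)cc2)c1` gives 10000 nM, while compound 2 `Fc1ccc(NC(=S)Nc2cccc(C(F)(F)F)c2)cc1` gives 31000 nM, the higher of the two numbers and so the less toxic result in this pair. Compound 3 `CC(=O)NC(=S)Nc1cccc(C(F)(F)F)c1` has not yet been measured. It has acetyl in place of 4-fluorophenyl on an amide-type nitrogen. Going by the values given here, only one measured step offers any guide: with fluoro in place of iodo on an aromatic carbon, the result is a 3.1-fold higher number from compound 1 to compound 2 (0.49 log units; beyond the scatter). Among the compounds with values here, that step bears on this change only loosely, since it kept the ring that now leaves, and no measured pair shows the loss of that ring. A modest rise in the same direction is therefore expected, with wide uncertainty. The expected step is a 2.3-fold higher number from compound 2 to compound 3 (0.35 log units; beyond the scatter). Compound 3 is estimated at 70000 nM, within an expected range from 20000 nM to 200000 nM.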

Compound 3, half-maximal cytotoxic concentration: > 100000 nM
Compound 3 ended at the assay's limit; the forecaster's own chance of this, stated with the estimate: 30%; middle value at least 1.4-fold (0.15 log units) away from the limit.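

In this assay, compound 3 reads as a limit of the assay and not as a number: the limit of > 100000 nM in this assay, at which 1 of the 3 values shown sits.

With acetyl in place of 4-fluorophenyl on the amide-type nitrogen, the result is an at least 3.2-fold higher number from compound 2 to compound 3 (0.50 log units; beyond the scatter), and with acetyl in place of 4-iodophenyl it is an at least 10-fold higher number from compound 1 to compound 3 (1.00 log units; beyond the scatter). The earlier pair changed only fluoro and iodo on that ring, whereas here the whole ring leaves and the read-out moves further toward lower toxicity in this test.

Going by these compounds, how far the true value of compound 3 lies past the limit remains unknown, so the full size of both steps stays open. On these data alone, it is also open whether the shift follows the loss of the ring or the arrival of the acetyl carbonyl, a question that a plain methyl or a longer alkyl chain on this nitrogen could help to separate.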